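Chloro in Place of Methyl: Compound 3 to Compound 4

The source may hold more compounds than are shown below. What is called first, only, known or untested is meant among the compounds shown, and "the series" means these compounds.

Compound 3 `COc1cc(-c2nc(SCc3cn(CC(=O)NC(=O)Nc4ccccn4)nn3)nc(Nc3ccc(C)cc3)c2C#N)cc(OC)c1OC` gives 7030 nM in a functional assay on MGC-803 cells (Homo sapiens) for inhibition, read by MTT assay, with a stated time of 72 h (a higher number here means a weaker inhibitor, a lower number a stronger inhibitor), the highest of the two numbers reported. Its nearest neighbour is compound 2 `Cc1ccc(Nc2nc(SCc3cn(CC(=O)NC(=O)Nc4ccccn4)nn3)nc(-c3ccc(C(C)C)cc3)c2C#N)cc1`, which gives 3360 nM. Compound 1 `CC(C)c1ccc(-c2nc(SCc3cn(CC(=O)NC(=O)Nc4ccccn4)nn3)nc(Nc3ccc(Cl)cc3)c2C#N)cc1` sits at the assay limit of > 64000 nM in this assay, at which 1 of the 3 values shown sits, and is reported as > 64000 nM, which is not a number. Compound 4 `COc1cc(-c2nc(SCc3cn(CC(=O)NC(=O)Nc4ccccn4)nn3)nc(Nc3ccc(Cl)cc3)c2C#N)cc(OC)c1OC` differs from compound 3 by chloro in place of methyl on an aromatic carbon. The measured step that bears on this is an at least 19-fold lower number from compound 1 to compound 2 (1.27 log units; beyond the scatter), the same exchange run in the opposite direction, whereas a 2.1-fold higher number from compound 2 to compound 3 (0.32 log units; beyond the scatter) does not involve it. A large rise in the number is therefore expected, quite possibly past the limit of this assay. For compound 4 the expected step is a 14-fold higher number from compound 3 to compound 4 (1.15 log units; beyond the scatter). Compound 4 is estimated at 100000 nM, within 30000 nM to 400000 nM.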

Compound 4, half-maximal inhibitory concentration: 17500 nM
Compound 4: middle estimate off by 5.7-fold (0.76 log units), on the high side; measured number below the stated range.
By their numbers in this assay, from the lowest: compound 2; then compound 3; then compound 4. At a limit, above all of these: compound 1.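

In this assay, chloro in place of methyl on the aromatic carbon raises the number on the 3,4,5-trimethoxyphenyl series too, with a 2.5-fold higher number from compound 3 to compound 4 (0.40 log units; beyond the scatter), so the direction of this change holds on both cores while its size does not: the same change on two cores in this assay, an at least 19-fold lower number (1.27 log units; beyond the scatter) from compound 1 to compound 2 and a 2.5-fold lower number (0.40 log units; beyond the scatter) from compound 4 to compound 3, at least 7.6-fold (0.88 log units) apart, beyond the scatter of two such steps. The exchange of 4-isopropylphenyl for 3,4,5-trimethoxyphenyl also depends on the group at this position, with an at least 3.6-fold lower number from compound 1 to compound 4 (0.56 log units; beyond the scatter) in the chloro series, opposite in direction to the step in the methyl series: the same change on two cores in this assay, a 2.1-fold higher number (0.32 log units; beyond the scatter) from compound 2 to compound 3 and an at least 3.6-fold lower number (0.56 log units; beyond the scatter) from compound 1 to compound 4, at least 7.6-fold (0.88 log units) apart, beyond the scatter of two such steps. Compound 1 gives > 64000 nM, which is a limit of the assay and not a number, so the steps from it are only minimum sizes.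

As far as these compounds go, whether a methoxy group or a bromine atom on this carbon would behave like methyl or like chloro remains open.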